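Extending the bromo-ended chain of compound 3

A few compounds are considered here, and "the series" means these few. Any claim that something is new, unique, unknown or untested is made for them only; others in the source may bear on it.

In a functional assay on MDA-MB-231 cells (Homo sapiens) for antiproliferative activity, read by MTT assay, with a stated time of 48 h (a lower number here means a stronger inhibitor, a higher number a weaker inhibitor), compound 1 `COc1ccc(N(C)c2ccnc(Cl)n2)cc1F` gives 1280 nM, compound 2 `COc1ccc(N(C)c2ccnc(Cl)n2)cc1O` gives 833 nM and compound 3 `COc1ccc(N(C)c2ccnc(Cl)n2)cc1OCCCCBr` gives 992 nM. Compound 3 cannot be separated from either of the others: a 1.2-fold higher number from compound 2 to compound 3 (0.08 log units; within the scatter) and a 1.3-fold lower number from compound 1 to compound 3 (0.11 log units; within the scatter) both stay within the scatter.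

Compound 4 `COc1ccc(N(C)c2ccnc(Cl)n2)cc1OCCCCCBr` differs from compound 3 by bromomethyl in place of bromo on a saturated chain carbon, four bonds along the chain from an oxygen on an aromatic ring. For the measured compounds named here, no measured pair varies chain length, so the evidence is indirect. Placing the whole 4-bromobutyl group on the oxygen of compound 2 gave only a 1.2-fold higher number from compound 2 to compound 3 (0.08 log units; within the scatter), and a 1.5-fold lower number from compound 1 to compound 2 (0.19 log units; within the scatter) also stays within the scatter. A smaller edit at the far end of that chain is therefore not expected to move this assay beyond the scatter, in either direction.

The expected change is a 1.1-fold lower number from compound 3 to compound 4 (0.04 log units; within the scatter), which would stay within the scatter. For compound 4 the estimated value is 900 nM, with an expected range of 450 nM to 1700 nM.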

Compound 4, half-maximal inhibitory concentration: > 10000 nM
Compound 4: only a limit was reported; the forecaster's own chance of this, stated with the estimate: 2%; at least 11-fold (1.04 log units) between middle value and limit.
By their numbers in this assay, from the lowest: compounds 2, 3 and 1 (each within the scatter of the next). At a limit, above all of these: compound 4.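

In this assay compound 4 is reported only as a limit, not as a number: the limit of > 10000 nM in this assay, at which 1 of the 4 values shown sits. Bromomethyl in place of bromo on a saturated chain carbon, four bonds along the chain from an oxygen on an aromatic ring, gives the first step of the series beyond the scatter, an at least 10-fold higher number from compound 3 to compound 4 (1.00 log units; beyond the scatter), whereas all steps among the earlier compounds stayed within it. Against the other two compounds the 5-bromopentyl ether also lies beyond the scatter, with an at least 12-fold higher number from compound 2 to compound 4 (1.07 log units; beyond the scatter) and an at least 7.8-fold higher number from compound 1 to compound 4 (0.89 log units; beyond the scatter), so the tolerance seen at this oxygen does not extend from 4-bromobutyl to 5-bromopentyl.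

The compounds shown leave open whether this is a sharp edge in chain length or part of a gradual trend, which 3-bromopropyl or a longer chain would address. They also leave open whether the bromo matters, which an amine in its place on the same chain would test.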